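A Ring Heteroatom Swap Tried on Two Cores

The source may report more compounds than this note shows. Statements on the series, on what has been measured and on what is new or still open speak of the compounds shown alone.

Compound 2 `COc1ccc(C2=NN(c3ccccc3)C(c3ccc(C)cc3)C2S(=O)(=O)CC2=NCCO2)cc1` and compound 3 `COc1ccc(C2=NN(c3ccccc3)C(c3ccc(C)cc3)C2S(=O)(=O)CC2=NCCS2)cc1` share one core and differ only by a group of 5 heavy atoms (3 carbon, 1 nitrogen, 1 sulfur; one five-membered non-aromatic ring with 2 hetero atoms) in place of a group of 5 heavy atoms (3 carbon, 1 nitrogen, 1 oxygen; one five-membered non-aromatic ring with 2 hetero atoms), on a saturated chain carbon bound to a sulfonyl sulfur. In a functional assay, read by Griess assay, with a stated time of 150 min, tested at 50 ug/mL (on this read-out higher numbers stand for a stronger effect at the one concentration tested and lower numbers for a weaker effect), compound 2 gives 59.1%, while compound 3 gives 39.4%; the step amounts to a number 19.7 percentage points lower from compound 2 to compound 3 (beyond the scatter). Compound 1 `O=S(=O)(CC1=NCCO1)C1C(c2ccc(Cl)cc2)=NN(c2ccccc2)C1c1ccc(Cl)cc1` rests on a second core, and the difference between the two cores is not broken down here. In this assay compound 1 was reported as "not active" (no number reported), with no number given. Compound 4 `O=S(=O)(CC1=NCCS1)C1C(c2ccc(Cl)cc2)=NN(c2ccccc2)C1c1ccc(Cl)cc1` arises from compound 1 by a group of 5 heavy atoms (3 carbon, 1 nitrogen, 1 sulfur; one five-membered non-aromatic ring with 2 hetero atoms) in place of a group of 5 heavy atoms (3 carbon, 1 nitrogen, 1 oxygen; one five-membered non-aromatic ring with 2 hetero atoms), on a saturated chain carbon bound to a sulfonyl sulfur, the same change that led from compound 2 to compound 3. Because that change produced a number 19.7 percentage points lower from compound 2 to compound 3 (beyond the scatter), and because compound 1 itself showed "not active" (no number reported), compound 4 is expected to remain weak in this assay. Compound 4 is estimated at 10%, expected to fall between 0% and 30%, with a real chance that again no number is reported.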

Compound 4, a percentage reported as activity, at one concentration (the size of the read-out at that concentration, not a potency): "not active" (no number reported)
The entry for compound 4 holds no number; the estimate stays without a comparison.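

Neither compound 1 nor compound 4 carries a number, so no step can be read between them. The compounds shown leave open whether this ring change acts on the core of compound 1 as it does on the core of compound 2. No measured evidence bears on this result.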